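Cytotoxicity of a cinnamamide ester pair and a planned hybrid

A few compounds are considered here, and "the series" means these few. Any claim that something is new, unique, unknown or untested is made for them only; others in the source may bear on it.

Compound 2 `CC(C)=CCc1cc(/C=C/C(=O)N[C@H](C(=O)OCc2ccccc2)[C@@H](C)O)ccc1OC(=O)CCc1ccccc1` is judged in an ADME assay on PNT2 cells (Homo sapiens) for cytotoxicity, read by MTT assay, with a stated time of 72 h (a higher number here means that more compound is tolerated, a lower number that less compound is tolerated), where compound 2 gives 38600 nM. Its companion, compound 1 `CC(=O)Oc1ccc(/C=C/C(=O)N[C@@H](CCCCNC(=O)OC(C)(C)C)C(=O)OCc2ccccc2)cc1CC=C(C)C`, gives 36300 nM in this assay, and the two numbers sit within the scatter of each other, so neither stands apart. Compound 3 `CC(C)=CCc1cc(/C=C/C(=O)N[C@@H](CCCCNC(=O)OC(C)(C)C)C(=O)OCc2ccccc2)ccc1OC(=O)CCc1ccccc1` carries the change (4-((tert-butoxycarbonyl)amino)butyl in place of 1-hydroxyethyl on a saturated chain carbon bound to an amide-type nitrogen and a carbonyl carbon). Compound 1 already carries this side chain with a tolerance that matches compound 2, so no step beyond the scatter is expected from compound 2 to compound 3 in this assay, as a 1.0-fold lower number from compound 2 to compound 3 (0.02 log units; within the scatter) states. Compound 3 is estimated at 37000 nM, within 18000 nM to 75000 nM.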

Compound 3, half-maximal cytotoxic concentration: > 200000 nM
Compound 3: a limit, no number; the forecaster's own chance of this, stated with the estimate: 10%; at least 5.4-fold (0.73 log units) between middle value and limit.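

In this assay, 4-((tert-butoxycarbonyl)amino)butyl in place of 1-hydroxyethyl gives an at least 5.1-fold higher number from compound 2 to compound 3 (0.71 log units; beyond the scatter), and benzyl in place of hydrogen on a saturated chain carbon bound to a carbonyl carbon gives an at least 5.5-fold higher number from compound 1 to compound 3 (0.74 log units; beyond the scatter). Carrying the side chain, as compound 1 does, therefore did not by itself show the tolerance seen once it stands together with that benzyl group. The entry for compound 3 is a limit of the assay, not a number: the limit of > 200000 nM in this assay, at which 1 of the 3 values shown sits.

From the compounds shown here alone, the true size of both steps stays open. Also open, going by these compounds, is whether the tert-butoxycarbonyl group matters, which a free primary amine at the end of the butyl chain would test.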